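Cyano replacing methyl on the aryl ring of compound 2

The compounds below may be only part of what the source reports. "The series", "measured", "known", "first", "only" and "open" are said of these compounds alone.

In a functional assay on C6 cells (Rattus norvegicus) for cytotoxicity, read by MTT assay, with a stated time of 24 h, tested at 12 ug/mL (on this read-out lower numbers stand for a stronger effect and higher numbers for a weaker effect at the one concentration tested), compound 2 `Cc1ccc(-c2cs/c(=N/NC(=O)CSc3nnnn3C)n2-c2ccccc2)cc1` gives 68.8%, the second highest of the three numbers. Compound 3 `O=C(CSc1nnnn1-c1ccccc1)N/N=c1/scc(-c2ccc(Cl)cc2)n1-c1ccccc1` gives 69.3%, within the scatter of compound 2, while compound 1 `Cc1ccc(-c2cs/c(=N/NC(=O)CSc3nnnn3-c3ccccc3)n2-c2ccccc2)cc1` gives 55.1%; the step of a number 13.7 percentage points higher from compound 1 to compound 2 (beyond the scatter) lies beyond the scatter. Compound 4 `Cn1nnnc1SCC(=O)N/N=c1/scc(-c2ccc(C#N)cc2)n1-c1ccccc1` differs from compound 2 by cyano in place of methyl on an aromatic carbon. Among the compounds with values here, no measured step involves a cyano group. The nearest guide is a change at the same place, a number 14.2 percentage points higher from compound 1 to compound 3 (beyond the scatter), a modest rise; a cyano group may act differently, so the expected step of a number 6.2 percentage points higher from compound 2 to compound 4 (within the scatter) is a small rise or none beyond the scatter. Compound 4 is therefore estimated at 75%, within 60% to 90%.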

Compound 4, a percentage reported as activity, at one concentration (the size of the read-out at that concentration, not a potency): 53.9%
Compound 4: the middle estimate sits 21.1 percentage points above what was measured, and the stated range ends above it.
By their numbers in this assay, from the lowest: compounds 4 and 1 (each within the scatter of the next); then compounds 2 and 3 (each within the scatter of the next).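

In this assay, the change from 4-methylphenyl to 4-cyanophenyl gives a number 14.9 percentage points lower from compound 2 to compound 4 (beyond the scatter), a stronger effect at the one concentration tested. Replacing methyl at this place can therefore move the read-out either way: chloro gave a number 14.2 percentage points higher from compound 1 to compound 3 (beyond the scatter), though with phenyl rather than methyl on the aromatic nitrogen. No evidence available here accounts for this difference in direction.

Still open, on these data alone, is whether cyano gives a similar step with phenyl on that nitrogen. As far as these compounds go, how an amine or a carboxylic acid would behave at this place is also open.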